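Oxadiazole series: amino-side-chain variants at the aromatic carbon

A few compounds are considered here, and "the series" means these few. Any claim that something is new, unique, unknown or untested is made for them only; others in the source may bear on it.

Measured so far:
- compound 1 `CCCCCCCCCCc1ccc(-c2noc([C@@H]3CCCN3)n2)cc1`: 21%
- compound 2 `CCCCCCCCCCc1ccc(-c2noc(C(Cl)CCN)n2)cc1`: 5%

In an assay on HeLa cells for inhibition of sphingosine-1-phosphate transporter SPNS2 (Mus musculus), read by LC-MS, tested at 2 uM (on this read-out higher numbers stand for more inhibition at the one concentration tested (going by the name of the read-out) and lower numbers for less inhibition), compound 1 gives 21% and compound 2 gives 5%. Among the measured compounds shown here, compound 2 stands lowest of the two numbers, with compound 1 as its only neighbour, and the step of a number 16 percentage points lower from compound 1 to compound 2 (beyond the scatter) is the one measured step in the set.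

Compound 3 `CCCCCCCCCCc1ccc(-c2noc(CC(O)CN)n2)cc1` is the next variant: a group of 5 heavy atoms (3 carbon, 1 nitrogen, 1 oxygen; no ring) in place of a group of 5 heavy atoms (3 carbon, 1 nitrogen, 1 chlorine; no ring), on an aromatic carbon. For the measured compounds named here, no measured step covers a change of this kind, as the only step available, a number 16 percentage points lower from compound 1 to compound 2 (beyond the scatter), swaps the five-membered non-aromatic ring for an open chain rather than exchanging one chain substituent for another. That step was modest and went downward; it offers no direct guide to the chlorine-for-oxygen exchange. The expectation for compound 3 is therefore a step of a number 5 percentage points higher from compound 2 to compound 3 (within the scatter), close to the scatter, with compound 3 estimated at 10% in this assay, within -5% to 28%.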

Compound 3, a percentage reported as inhibition, at one concentration (the size of the read-out at that concentration, not a potency): 59%
For compound 3 the middle estimate is 49 percentage points below the measured one, and the stated range ends below it.
By their numbers in this assay, from the lowest: compound 2; then compound 1; then compound 3.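

In this assay an open chain at this position is no loss in itself: a number 38 percentage points higher from compound 1 to compound 3 (beyond the scatter) and the fall seen with compound 2 therefore does not extend to every open chain. What the chain carries matters greatly, with a number 54 percentage points higher from compound 2 to compound 3 (beyond the scatter) when 3-amino-2-hydroxypropyl, with 2 hydrogen-bond donors and 2 hydrogen-bond acceptors, replaces a chlorine-bearing chain with 1 of each. Nothing available gives a reason for this rise.

The chains of compound 2 and compound 3 also differ in where the chlorine and the oxygen stand along them, so the exchange of atom and the change in chain arrangement remain unseparated. Also open, on these data alone, is how the series responds to a methoxy group in place of the hydroxyl, or to a longer chain ending in the amine.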